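This account rests on a few compounds, and the source may have more. Where it says the series, first, only, none or still open, it means among the compounds named here.

Measured in an assay on isolated protein for inhibition of retinal dehydrogenase 2 (Homo sapiens); a higher number here means a weaker inhibitor, a lower number a stronger inhibitor:
compound 1 `CC(Sc1nc2c(cnn2C)c(=O)n1-c1ccccc1)c1cccc(F)c1`: 110 nM
compound 2 `CCC(Sc1nc2c(cnn2C)c(=O)n1-c1ccccc1)c1ccccc1`: 179 nM
compound 3 `CC(Sc1nc2c(cnn2C)c(=O)n1-c1ccc(CO)cc1)c1ccccc1`: 600 nM

Compound 3 carries the highest number of the three; compound 2 and compound 1 sit at lower numbers, both gaps beyond the scatter. Compound 4 `CC(Sc1nc2c(cnn2C)c(=O)n1-c1ccc(C#N)cc1)c1ccccc1` is not yet measured. It differs from compound 3 by cyano in place of hydroxymethyl on an aromatic carbon. Within the data shown here, the only measured single-change step, a 1.6-fold higher number from compound 1 to compound 2 (0.21 log units; within the scatter), alters the group on sulfur and leaves the aryl untouched, so it does not bear on this change; compounds 1 and 2 differ from compound 3 in two places and offer no clean comparison. Among the measured compounds shown here, no step in the data sizes a swap on the aryl. Compound 4 is therefore expected somewhere within the range already seen, a 2.0-fold lower number from compound 3 to compound 4 (0.30 log units; within the scatter), with wide uncertainty. The estimate for compound 4 is 300 nM, expected between 100 nM and 900 nM.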

Compound 4, half-maximal inhibitory concentration: 3100 nM
Estimate against measurement, compound 4: 10-fold (1.01 log units) below; the measured number lies above the stated range.
By their numbers in this assay, from the lowest: compounds 1 and 2 (each within the scatter of the next); then compound 3; then compound 4.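

In this assay, among these compounds, the position para to a large group on the aryl responds to substitution: the change from 4-(hydroxymethyl)phenyl to 4-cyanophenyl gives a 5.2-fold higher number from compound 3 to compound 4 (0.71 log units; beyond the scatter) and is the first step beyond the scatter. Heavy-atom count stays the same across this swap, while the hydrogen-bond donor of hydroxymethyl is lost. No measurement here bears on why the number rises.

Open, from the compounds shown here alone, is where an amine, a carboxylic acid or a longer chain such as hydroxyethyl at this position would fall. Also open, going by these compounds, is how the unsubstituted phenyl compares with compound 3 and compound 4 when the sulfur group is held constant.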